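The source may hold more compounds than are shown below. What is called first, only, known or untested is meant among the compounds shown, and "the series" means these compounds.

Within the data shown here, compound 1, drawn as `Cc1ccc(-c2csc(NC(=O)COc3ccccc3)n2)cc1`, is one of three compounds measured so far in a functional assay on Ehrlich cells (Mus musculus) for cytotoxicity, read by MTT assay, with a stated time of 48 h; a lower number here means a stronger inhibitor, a higher number a weaker inhibitor. Compound 1 gives 50100 nM, which places it second highest of the three numbers. Compound 2, `Cc1ccc(-c2csc(NC(=O)COc3ccccc3C)n2)cc1`, gives 54400 nM, and the step of a 1.1-fold higher number from compound 1 to compound 2 (0.04 log units; within the scatter) is a methyl in place of hydrogen on an aromatic carbon. Compound 3, `Cc1ccc(-c2csc(NC(=O)COc3ccc(F)cc3)n2)cc1`, gives 18400 nM; the step of a 2.7-fold lower number from compound 1 to compound 3 (0.44 log units; beyond the scatter) is a fluoro in place of hydrogen on an aromatic carbon, and the step of a 3.0-fold lower number from compound 2 to compound 3 (0.47 log units; beyond the scatter) exchanges the whole phenyl on the oxygen.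

Compound 4, `O=C(COc1ccccc1)Nc1nc(-c2ccc(Cl)cc2)cs1`, has not yet been measured. Compared with compound 1 the change is chloro in place of methyl on an aromatic carbon. Among the measured compounds shown here, all three measured steps alter the ring that hangs from the oxygen, whereas the change to compound 4 sits on the other ring, which no measured pair has varied. For the measured compounds named here, the only halogen step, from compound 1 to compound 3, was modest, so no strong shift is expected here. The estimate for compound 4 in this assay is 35000 nM, with a range from 12000 nM to 90000 nM, a step of a 1.4-fold lower number from compound 1 to compound 4 (0.16 log units; within the scatter) that is expected to stay close to the scatter.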

Compound 4, half-maximal inhibitory concentration: 55500 nM
For compound 4 the middle estimate is 1.6-fold (0.20 log units) below the measured one; low and high end bracket the measured number.
By their numbers in this assay, from the lowest: compound 3; then compounds 1, 2 and 4 (each within the scatter of the next).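

In this assay, among these compounds, exchanging 4-methylphenyl for 4-chlorophenyl gives a 1.1-fold higher number from compound 1 to compound 4 (0.04 log units; within the scatter), the first measured change on this ring, and at this one place, para to a large group, methyl and chloro cannot be told apart. The halogen swap here therefore does not repeat the step seen with fluoro on the ring attached through the oxygen, which gave a 2.7-fold lower number from compound 1 to compound 3 (0.44 log units; beyond the scatter), though these are different halogens, replacing different groups, on different rings, so the two steps show no general rule about halogens. No measurement at hand explains why methyl and chloro read alike here.

This single pair cannot show whether the position tolerates any group or merely these two, so an amine, a carboxylic acid, a methoxy group or a longer chain at the same place could still move the number in either direction. As far as these compounds go, it also remains open whether 4-chlorophenyl would leave the number just as unchanged when the ring on the oxygen carries the fluoro of compound 3.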